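Removing a Methoxy Group Where Nothing Inhibits

This account rests on a few compounds, and the source may have more. Where it says the series, first, only, none or still open, it means among the compounds named here.

Compound 1 `COc1ccccc1-c1csc(N/N=C/c2ccc(F)c(F)c2)n1` was tested in an ADME assay on HUVEC cells (Homo sapiens) for inhibition, read by MTT assay, with a stated time of 48 h; on this read-out higher numbers stand for weaker inhibition and lower numbers for stronger inhibition. In this assay compound 1 gives > 100000 nM, which is a limit of the assay and not a number. Two related compounds show the same outcome. Compound 2 `COc1cc(/C=N/Nc2nc(-c3cccc(Br)c3)cs2)c(Br)c(Br)c1OC` gives > 100000 nM in this assay, again a limit rather than a number. Compound 3 `COc1cc(/C=N/Nc2nc(-c3cc(C(F)(F)F)cc(C(F)(F)F)c3)cs2)cc(Br)c1OC` gives > 100000 nM in this assay, also a limit. For the measured compounds named here, all three measured compounds therefore sit at the limit of > 100000 nM in this assay, at which 3 of the 3 values shown sit, so no step between measured compounds can be counted, and compound 1 stands nowhere above or below its neighbours.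

Compound 4 `Fc1ccc(/C=N/Nc2nc(-c3ccccc3)cs2)cc1F` has not yet been measured. It differs from compound 1 in one place: hydrogen in place of methoxy on an aromatic carbon. Cut one bond further out, the same change reads as 2-methoxyphenyl to phenyl.

Going by the values given here, with no measured step to lean on, the expectation rests only on where the measured compounds stand. Because compound 1, compound 2 and compound 3 all sit at the limit of > 100000 nM in this assay, at which 3 of the 3 values shown sit, the step in this assay is expected to be none beyond the scatter, with the expected step being a number no higher from compound 1 to compound 4 (the limit leaves the size open). Compound 4 is therefore estimated at 100000 nM, with a range from 50000 nM to 300000 nM, and it is most likely to be reported again only as a limit.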

Compound 4, half-maximal inhibitory concentration: > 100000 nM
Compound 4 ended at the assay's limit; the forecaster's own chance of this, stated with the estimate: 85%; the middle value lies on the limit itself.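

In this assay compound 4 gives > 100000 nM, which is a limit of the assay and not a number. For the compounds shown here, compound 1 also stands at a limit, so no step from compound 1 to compound 4 can be read: the limit of > 100000 nM in this assay, at which 4 of the 4 values shown sit. The compounds shown leave open whether replacing methoxy with hydrogen changes inhibition at all.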